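This account rests on a few compounds, and the source may have more. Where it says the series, first, only, none or still open, it means among the compounds named here.

Among the compounds with values here, in a functional assay on HepG2 cells (Homo sapiens) for cytotoxicity, read by sulforhodamine B assay, with a stated time of 24 h (a lower number here means a stronger inhibitor, a higher number a weaker inhibitor), three compounds with a shared core have numbers so far. Compound 1 `O=C1Nc2ccc(S(=O)(=O)N3CCOCC3)cc2/C1=N/c1ccc(Br)cc1` gives 11900 nM, compound 2 `N/N=C1\C(=O)Nc2ccc(S(=O)(=O)N3CCOCC3)cc21` gives 32400 nM, and compound 3 `CC(=O)c1cccc(/N=C2\C(=O)Nc3ccc(S(=O)(=O)N4CCOCC4)cc32)c1` gives 28600 nM. Compound 3 thus sits with compound 2 at the upper end of these numbers: a 1.1-fold lower number from compound 2 to compound 3 (0.05 log units; within the scatter) lies within the scatter, while a 2.4-fold higher number from compound 1 to compound 3 (0.38 log units; beyond the scatter) lies beyond it.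

Compound 4 `O=C1Nc2ccc(S(=O)(=O)N3CCOCC3)cc2/C1=N/NS(=O)(=O)c1ccccc1` differs from compound 3 by (phenylsulfonyl)amino in place of 3-acetylphenyl on a double-bonded nitrogen, which puts (phenylsulfonyl)amino in place of 3-acetylphenyl on a double-bonded nitrogen. Within the data shown here, no measured step makes this exact exchange. The closest evidence is the other exchanges at that nitrogen: a 2.7-fold higher number from compound 1 to compound 2 (0.43 log units; beyond the scatter) and the step to compound 3 from compound 1 were modest, and the step from compound 2 was within the scatter. As far as these compounds go, on that evidence, no step beyond the scatter is expected in this assay, and the direction remains open. The expected step is a 1.1-fold lower number from compound 3 to compound 4 (0.06 log units; within the scatter). For compound 4 the estimated value is 25000 nM, with an expected range from 10000 nM to 60000 nM.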

Compound 4, half-maximal inhibitory concentration: 23900 nM
Compound 4: the middle estimate sits 1.0-fold (0.02 log units) above what was measured; the measured number falls inside the stated range.
By their numbers in this assay, from the lowest: compounds 1, 4, 3 and 2 (each within the scatter of the next, the first and the last beyond it).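

In this assay, (phenylsulfonyl)amino on the double-bonded nitrogen cannot be told apart from any of the three earlier groups: a 1.2-fold lower number from compound 3 to compound 4 (0.08 log units; within the scatter), a 1.4-fold lower number from compound 2 to compound 4 (0.13 log units; within the scatter) and a 2.0-fold higher number from compound 1 to compound 4 (0.30 log units; within the scatter). Compounds 2 and 3 each lie beyond the scatter from compound 1, whereas compound 4 lies within it of all three, so phenylsulfonyl in place of hydrogen on the amine nitrogen produces no readable step, and compound 4 does not side with either end of the series. Nothing available explains these numbers.

The compounds shown leave open whether a methylsulfonyl group in place of phenylsulfonyl, or a carboxylic acid or an amine on that phenyl ring, would give a step beyond the scatter. They also leave open whether any group at this nitrogen can take the number well below that of compound 1, at 11900 nM.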